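Swapping the Benzamido Group for a Smaller Chain

This account rests on a few compounds, and the source may have more. Where it says the series, first, only, none or still open, it means among the compounds named here.

Measured compounds:
compound 1 `N#CC1=C(NC(=O)c2ccccc2)N(c2ccc(S(N)(=O)=O)cc2)C2=C(C(=O)CCC2)C1c1ccc(Cl)cc1Cl` — 75%
compound 2 `NC1=C(C(=O)O)C(c2ccc(Cl)cc2Cl)C2=C(CCCC2=O)N1c1ccc(S(N)(=O)=O)cc1` — 60%

In a functional assay on Ehrlich cells (Mus musculus) for cytotoxicity, read by trypan blue exclusion, with a stated time of 2 h, tested at 100 ug/mL (a lower number here means a weaker effect, a higher number a stronger effect of the compound at the concentration tested), compound 1 gives 75%, the higher of the two numbers; compound 2 gives 60%, a gap beyond the usual scatter. Compound 3 `CCO/C=N/C1=C(C#N)C(c2ccc(Cl)cc2Cl)C2=C(CCCC2=O)N1c1ccc(S(N)(=O)=O)cc1` is not yet measured. It differs from compound 1 in one place: a group of 5 heavy atoms (3 carbon, 1 nitrogen, 1 oxygen; no ring) in place of a group of 9 heavy atoms (7 carbon, 1 nitrogen, 1 oxygen; one six-membered aromatic ring of carbon only), on a double-bonded ring carbon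

Among the compounds with values here, no measured pair shows the effect of such a change, so the expectation rests on compound 1 alone. The step of a number 7 percentage points lower from compound 1 to compound 3 (within the scatter) is expected to be small, downward if anything, and quite possibly within the scatter. Compound 3 is estimated at 68%, in the range 50% to 85%.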

Compound 3, a percentage reported as activity, at one concentration (the size of the read-out at that concentration, not a potency): 40%
For compound 3 the middle estimate is 28 percentage points above the measured one, and the stated range ends above it.
By their numbers in this assay, from the lowest: compound 3; then compound 2; then compound 1.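

In this assay, putting a group of 5 heavy atoms with no ring in place of the benzamido group on this double-bonded ring carbon gives a number 35 percentage points lower from compound 1 to compound 3 (beyond the scatter), so the reading is sensitive to what this carbon carries. The change removes the aromatic ring and the hydrogen-bond donor together, and the two compounds cannot separate these. Nothing measured here gives a reason for the drop. 

From the compounds shown here alone, an acetamido group, which has no aromatic ring but keeps the amide hydrogen, would show which loss matters, and that remains open.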